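The source may hold more compounds than are shown below. What is called first, only, known or untested is meant among the compounds shown, and "the series" means these compounds.

The three measured compounds share one scaffold and differ only at two points. Compound 1 `FC(F)(F)Oc1ccc(-c2ccc(-c3ccc(-c4nc5ccccc5[nH]4)cc3)cc2)cc1` carries a trifluoromethoxy group at one end and an unsubstituted benzimidazole at the other; in a functional assay on A2780 cells (Homo sapiens) for inhibition, read by sulforhodamine B assay (on this read-out lower numbers stand for stronger inhibition of growth and higher numbers for weaker inhibition of growth), compound 1 gives 100000 nM. Compound 2 `Oc1ccc(-c2ccc(-c3ccc(-c4nc5ccccc5[nH]4)cc3)cc2)cc1` replaces the trifluoromethyl on the oxygen with hydrogen, the difference reading (hydrogen in place of trifluoromethyl on an oxygen on an aromatic ring), and in this assay compound 2 gives 36000 nM; the step is a 2.8-fold lower number from compound 1 to compound 2 (0.44 log units; beyond the scatter). Compound 3 `Cc1ccc2[nH]c(-c3ccc(-c4ccc(-c5ccc(OC(F)(F)F)cc5)cc4)cc3)nc2c1` keeps the trifluoromethoxy group but adds a methyl to the core, the difference being (methyl in place of hydrogen on an aromatic carbon); in this assay compound 3 gives 12300 nM, a step of an 8.1-fold lower number from compound 1 to compound 3 (0.91 log units; beyond the scatter), and compound 3 stands with the lowest number of the three.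

Compound 4 `Cc1ccc2[nH]c(-c3ccc(-c4ccc(-c5ccc(O)cc5)cc4)cc3)nc2c1` has not yet been measured. It differs from compound 3 by hydrogen in place of trifluoromethyl on an oxygen on an aromatic ring, and this is the same change that was made from compound 1 to compound 2, at the same place; it occurs twice among these compounds. The two cores differ by the methyl described under (methyl in place of hydrogen on an aromatic carbon).

Because the earlier step was a 2.8-fold lower number from compound 1 to compound 2 (0.44 log units; beyond the scatter), a step of similar size is expected from compound 3 to compound 4, namely a 2.7-fold lower number from compound 3 to compound 4 (0.44 log units; beyond the scatter). This rests on a single precedent, so the range is kept wide. Compound 4 is therefore estimated to give 4500 nM in this assay, expected between 1500 nM and 12000 nM.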

Compound 4, concentration for 50% growth inhibition: 31200 nM
The estimate for compound 4 lay 6.9-fold (0.84 log units) below the measured number, outside the stated range (above it).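

In this assay, the change from trifluoromethoxy to hydroxy does not carry over from one core to the other: on the methyl-bearing core it gives a 2.5-fold higher number from compound 3 to compound 4 (0.40 log units; beyond the scatter), opposite in direction to the step on the core of compound 1: the same change on two cores in this assay, a 2.8-fold lower number (0.44 log units; beyond the scatter) from compound 1 to compound 2 and a 2.5-fold higher number (0.40 log units; beyond the scatter) from compound 3 to compound 4, 7.0-fold (0.85 log units) apart, beyond the scatter of two such steps. The methyl does not carry over either, for with hydroxy in place it gives only a 1.2-fold lower number from compound 2 to compound 4 (0.06 log units; within the scatter), while with trifluoromethoxy in place its step is beyond the scatter: the same change on two cores in this assay, an 8.1-fold lower number (0.91 log units; beyond the scatter) from compound 1 to compound 3 and a 1.2-fold lower number (0.06 log units; within the scatter) from compound 2 to compound 4, 7.0-fold (0.85 log units) apart, beyond the scatter of two such steps. Across these four compounds the two changes therefore do not act independently, so neither step can be transferred on its own, but each comparison rests on a single pair of steps, and the numbers show neither why the two changes depend on each other nor whether this holds for any other group.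

The compounds shown leave open whether the methyl step is tied to trifluoromethoxy in particular or would also appear with another group at that place, such as methoxy, an amine or a carboxylic acid. They also leave open whether chlorine or a longer alkyl chain in place of the methyl would show the same dependence.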